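The source may hold more compounds than are shown below. What is called first, only, known or untested is meant among the compounds shown, and "the series" means these compounds.

Measured so far in a functional assay on SW620/5-FU cells (Homo sapiens) for cytotoxicity, read by MTT assay, with a stated time of 48 h, in the presence of a further agent that is not named here; on this read-out higher numbers stand for an effect only at larger amounts of compound and lower numbers for an effect already at smaller amounts:

compound 1, `Cn1ncc2c(-c3ccccc3)cc(NNC(=O)Nc3cc(Cl)nc(Cl)c3)nc21`: 76900 nM
compound 2, `CCN(CC)c1cc(NC(=O)NNc2cc(-c3ccc(F)cc3)c3cnn(C)c3n2)cc(Cl)n1`: 37000 nM

Compound 1 stands with the highest of the two numbers; the nearest is compound 2, whose number lies lower by a gap beyond the scatter. Among the measured compounds shown here, the two measured compounds differ from each other in several places at once, so no single step between them is available to guide the next change.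

Compound 3, `Cn1nc(C(F)(F)F)c2c(-c3ccccc3)cc(NNC(=O)Nc3cc(Cl)nc(Cl)c3)nc21`, differs from compound 1 by trifluoromethyl in place of hydrogen on an aromatic carbon. The shared core and the rest of the molecule are untouched. For the measured compounds named here, with no measured pair showing this kind of change, the expectation rests on compound 1 alone and carries a wide range. For compound 3 the estimated value in this assay is 60000 nM, with a range from 20000 nM to 180000 nM. The expected step of a 1.3-fold lower number from compound 1 to compound 3 (0.11 log units; within the scatter) is small and within the scatter, in no firm direction.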

Compound 3, half-maximal effective concentration: 13100 nM
Estimate against measurement, compound 3: 4.6-fold (0.66 log units) above, outside the stated range (below it).
By their numbers in this assay, from the lowest: compound 3; then compound 2; then compound 1.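

In this assay, among the compounds shown here, trifluoromethyl in place of hydrogen on an aromatic carbon gives a 5.9-fold lower number from compound 1 to compound 3 (0.77 log units; beyond the scatter) and provides the first single-place step. This carbon, on a five-membered aromatic ring and two ring bonds from the ring atom that bears a methyl group, therefore accepts the added group, and the number moves lower rather than higher. The shared core and the rest of the molecule stay the same, so the step belongs to this one change, but no measurement shown bears on why the number moves.

On these data alone, whether the step is specific to trifluoromethyl, or would also appear with a methyl group, chlorine or a nitrile on this carbon, remains open. Also open, as far as these compounds go, is whether the same change would lower the number on compound 2, which carries a diethylamino group and a 4-fluorophenyl group.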